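Swapping Trifluoromethyl for Methanesulfonamido on a Pyrazole Urea

The source may hold more compounds than are shown below. What is called first, only, known or untested is meant among the compounds shown, and "the series" means these compounds.

Compound 1 `Cc1ccccc1NC(=O)Nc1cc(C(C)(C)C)nn1-c1ccccc1`: 8.6 degrees C
Compound 2 `CC(C)(C)c1cc(NC(=O)Nc2ccc(Cl)cc2)n(-c2ccc(C(F)(F)F)cc2)n1`: -0.6 degrees C

Both measurements come from an assay on isolated protein for inhibition of serine/threonine-protein kinase 10 (Homo sapiens), read by thermal shift assay, tested at 10 uM; on this read-out lower numbers stand for weaker stabilisation of the target and higher numbers for stronger stabilisation of the target against heat. Compound 2 gives the lower of the two values, and compound 1 stands a fair way above it, a gap well beyond the scatter. Compound 3 `CC(C)(C)c1cc(NC(=O)Nc2ccc(Cl)cc2)n(-c2ccc(NS(C)(=O)=O)cc2)n1` differs from compound 2 in one place: methanesulfonamido in place of trifluoromethyl on an aromatic carbon. Within the data shown here, no measured pair shows this exact change, so only a guess is possible. A small upward step a number 2.1 degrees C higher from compound 2 to compound 3 (beyond the scatter) is expected, though one barely beyond the scatter. Compound 3 is therefore estimated at 1.5 degrees C, within a range from -1 degrees C to 5 degrees C.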

Compound 3, shift of the target's melting temperature: 8.9 degrees C
Compound 3: middle estimate off by 7.4 degrees C, on the low side, and the stated range ends below it.
By their numbers in this assay, from the lowest: compound 2; then compounds 1 and 3 (each within the scatter of the next).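

In this assay, putting methanesulfonamido in place of trifluoromethyl on this aromatic carbon, para to a large group, gives a large gain: a number 9.5 degrees C higher from compound 2 to compound 3 (beyond the scatter). With the rest of the molecule unchanged, this single position can turn a compound with almost no shift into one that strongly stabilises the target. On these data alone, whether an amine or a carboxylic acid on this carbon would give a similar shift remains open, as does whether the same swap would work on other ureas. Nothing shown here explains the size of this step.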